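The compounds below may be only part of what the source reports. "The series", "measured", "known", "first", "only" and "open" are said of these compounds alone.

Measured in a functional assay on MKN-74 cells (Homo sapiens) for antiproliferative activity, with a stated time of 24 h; on this read-out higher numbers stand for weaker inhibition and lower numbers for stronger inhibition:
- compound 1 `Cc1ccccc1CN1CCc2c(sc(NC(=O)c3ccccc3Cl)c2C(N)=O)C1`: compound 1 reaches only the limit > 50000 nM, one of the values at the limit of > 50000 nM in this assay, at which 1 of the 3 values shown sits.
- compound 2 `NC(=O)c1c(NC(=O)c2ccccc2Cl)sc2c1CCN(Cc1ccccc1Cl)C2`: compound 2 gives 4430 nM
- compound 3 `COc1ccc(NC(=S)N2CCc3c(sc(NC(=O)c4ccccc4Cl)c3C(N)=O)C2)cc1`: compound 3 gives 19600 nM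

Compound 2 stands lowest of the two numbers in this assay; its nearest neighbour is compound 3, with a 4.4-fold higher number from compound 2 to compound 3 (0.65 log units; beyond the scatter). The next compound, compound 4 `NC(=O)c1c(NC(=O)c2ccccc2Cl)sc2c1CCN(C(=S)Nc1c(Cl)cccc1Cl)C2`, differs from compound 2 by a group of 11 heavy atoms (7 carbon, 1 nitrogen, 1 sulfur, 2 chlorine; one six-membered aromatic ring of carbon only) in place of a group of 8 heavy atoms (7 carbon, 1 chlorine; one six-membered aromatic ring of carbon only), on an amine nitrogen in a ring. Going by the values given here, two measured steps bear on this change at the same ring nitrogen: a 4.4-fold higher number from compound 2 to compound 3 (0.65 log units; beyond the scatter), and an at least 2.5-fold lower number from compound 1 to compound 3 (0.40 log units; beyond the scatter), the latter starting from a limit. Both point to a thiourea at this position sitting higher than the chlorobenzyl of compound 2, so a modest rise in this assay is expected, a 2.7-fold higher number from compound 2 to compound 4 (0.43 log units; beyond the scatter). Compound 4 is accordingly estimated at 12000 nM, with a range of 4000 nM to 40000 nM.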

Compound 4, half-maximal inhibitory concentration: 4020 nM
Compound 4: middle estimate off by 3.0-fold (0.47 log units), on the high side; measured number inside the range.
By their numbers in this assay, from the lowest: compounds 4 and 2 (each within the scatter of the next); then compound 3. At a limit, above all of these: compound 1.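

Against the 2-chlorobenzyl, a thiourea at the ring nitrogen carries no penalty of its own: a 1.1-fold lower number from compound 2 to compound 4 (0.04 log units; within the scatter). Among the thioureas the aryl group matters, with 2,6-dichlorophenyl in place of 4-methoxyphenyl giving a 4.9-fold lower number from compound 3 to compound 4 (0.69 log units; beyond the scatter). There is also an at least 12-fold lower number from compound 1 to compound 4 (1.09 log units; beyond the scatter), which starts from a limit and not from a number: the limit of > 50000 nM in this assay, at which 1 of the 4 values shown sits.

Open, from the compounds shown here alone, is whether a single chloro on that phenyl, or a carboxylic acid there, would hold the number near that of compound 4. Also open, going by these compounds, is whether a urea, with oxygen in place of the thiourea sulfur, behaves alike on this ring nitrogen.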